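A few compounds are considered here, and "the series" means these few. Any claim that something is new, unique, unknown or untested is made for them only; others in the source may bear on it.

Compound 1 `CCSC[C@@](O)([C@@H](Nc1cccc2nc(C)ccc12)c1ccc(OC)c(F)c1)C(F)(F)F`: 82%
Compound 2 `CCSC[C@@](O)([C@@H](Nc1cccc2nc(C)ccc12)c1ccc(Cl)c(F)c1OC)C(F)(F)F`: 82%

Within the data shown here, in a functional assay on THP-1 cells (Homo sapiens) (on this read-out lower numbers stand for smaller maximal responses and higher numbers for larger maximal responses), compound 2 gives 82%, level with compound 1, the only other compound measured; the step of no change at the digits printed from compound 1 to compound 2 (within the scatter). Compound 3 `CCSC[C@@](O)([C@@H](Nc1cccc2nc(C)ccc12)c1ccc(Cl)c(F)c1O)C(F)(F)F` differs from compound 2 by hydrogen in place of methyl on an oxygen on an aromatic ring. Among the measured compounds shown here, the one measured step concerns a different change at another part of the molecule, so no measured step bears on this one. With nothing pointing either way, a step of no change at the digits printed from compound 2 to compound 3 (within the scatter) is expected, none beyond the scatter. Compound 3 is therefore estimated at 82%, with a range from 65% to 95%.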

Compound 3, largest response reached (Emax), in percent of the reference or control that the assay uses in the THP-1 assay: 107%
Compound 3: middle estimate off by 25 percentage points, on the low side; measured number outside the range, above it.
By their numbers in the THP-1 assay, from the lowest: compounds 1 and 2 (each within the scatter of the next); then compound 3.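

Methoxy to hydroxy on an oxygen on an aromatic ring is the first change here to move the THP-1 assay: the step is a number 25 percentage points higher from compound 2 to compound 3 (beyond the scatter), and measured against the other methoxy compound it is a number 25 percentage points higher from compound 1 to compound 3 (beyond the scatter). In a physicochemical assay for lipophilicity (on this read-out lower numbers stand for lower lipophilicity and higher numbers for higher lipophilicity), compound 2 gives 5.3 and compound 3 gives 3.4. The same change thus comes with lower lipophilicity as well as a larger maximal response: the measured partition coefficient of compound 2, 5.3, and of compound 3, 3.4, a number 1.90 log units lower (beyond the scatter)

This single pair cannot separate the free hydroxy from the lower lipophilicity as the source of the rise. From the compounds shown here alone, whether an amine or a carboxylic acid in place of the hydroxy would keep that response stays open.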